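Double ester prodrugs of a carbapenem: plasma stability notes

A few compounds are considered here, and "the series" means these few. Any claim that something is new, unique, unknown or untested is made for them only; others in the source may bear on it.

Measured compounds in an ADME assay on a cell-free system (plasma, Homo sapiens) for metabolic stability, read by LC-MS, with a stated time of 60 min, at 37 degrees C, tested at 50 uM; on this read-out lower numbers stand for a less stable compound and higher numbers for a more stable compound:
compound 1 `CC(C)C(=O)OCOC(=O)C1=C(S[C@@H]2CN[C@H](C(=O)Nc3cccc(C(=O)O)c3)C2)[C@H](C)[C@@H]2[C@@H]([C@@H](C)O)C(=O)N12` gives 15%
compound 2 `C[C@@H](O)[C@H]1C(=O)N2C(C(=O)OCOC(=O)C(C)(C)C)=C(S[C@@H]3CN[C@H](C(=O)Nc4cccc(C(=O)O)c4)C3)[C@H](C)[C@H]12` gives 45%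
compound 3 `C[C@@H](O)[C@H]1C(=O)N2C(C(=O)OCOC(=O)OC(C)(C)C)=C(S[C@@H]3CN[C@H](C(=O)Nc4cccc(C(=O)O)c4)C3)[C@H](C)[C@H]12` gives 40%

Compound 3 sits second highest of the three numbers in this assay; its nearest neighbour is compound 2, with a number 5 percentage points lower from compound 2 to compound 3 (within the scatter), a gap inside the scatter, while the step of a number 25 percentage points higher from compound 1 to compound 3 (beyond the scatter) lies beyond it. Among the measured compounds shown here, the only other measured step, a number 30 percentage points higher from compound 1 to compound 2 (beyond the scatter), also concerns the acyl part of the same ester.

Compound 4 `C[C@@H](O)[C@H]1C(=O)N2C(C(=O)OCOC(=O)OC(C)(C)C)=C(S[C@@H]3CN[C@H](C(=O)Nc4cccc(C(=O)OCOC(=O)OC(C)(C)C)c4)C3)[C@H](C)[C@H]12` differs from compound 3 by ((tert-butoxycarbonyl)oxy)methyl in place of hydrogen on an oxygen next to a carbonyl group. For the measured compounds named here, none of the measured steps alters this position; all three change only the group on the carbonyl carbon of the existing ester. The measured steps therefore give no direct guide. Since compound 4 now carries two such ester linkages instead of one, a modest fall in the remaining fraction is expected rather than a rise, with wide uncertainty.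

For compound 4 the estimate in this assay is 30%, range 10% to 50%; the step from compound 3 is expected to be a number 10 percentage points lower from compound 3 to compound 4 (within the scatter).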

Compound 4, percent of the compound remaining: 67%
The estimate for compound 4 lay 37 percentage points below the measured number; the whole stated range lies below it.
By their numbers in this assay, from the lowest: compound 1; then compounds 3 and 2 (each within the scatter of the next); then compound 4.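

In this assay, among the compounds shown here, ((tert-butoxycarbonyl)oxy)methyl in place of hydrogen on an oxygen next to a carbonyl group gives a number 27 percentage points higher from compound 3 to compound 4 (beyond the scatter), so this position also bears on the read-out, which the earlier steps could not show because they changed only the group on the carbonyl carbon of the existing ester. A second ester linkage of this kind therefore goes with a higher number here, not a lower one, though this rests on a single pair of compounds. Nothing available accounts for the rise.

On these data alone, whether a smaller group on this oxygen, such as ethyl, or a longer chain in the same place would move the number in the same direction remains open. So does which of the two ester linkages is lost first.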